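The compounds below may be only part of what the source reports. "The series", "measured", "known", "first", "only" and "open" are said of these compounds alone.

Of the compounds shown here, two with a shared core have so far been measured in a functional assay on brain (Rattus norvegicus, strain Wistar) for inhibition; a lower number here means a stronger inhibitor, a higher number a weaker inhibitor. Compound 1 `CCCCCCCc1ccc(-c2c(C)[nH]c(=O)n2C2CCCCC2)cc1`, which carries a heptyl group, gives 8700 nM. Compound 2 `Cc1[nH]c(=O)n(C2CCCCC2)c1-c1ccc(-c2ccccc2)cc1`, which carries a phenyl group in that place, gives 10900 nM. These two numbers lie within the usual scatter of each other, so compound 2 cannot be ranked against compound 1.

The next compound, compound 3 `Cc1[nH]c(=O)n(C2CCCCC2)c1-c1ccc(Oc2ccccc2)cc1`, keeps all of compound 2 except one group: phenoxy in place of phenyl on an aromatic carbon. In words, it has phenoxy in place of phenyl on an aromatic carbon, para to a large group.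

For the measured compounds named here, only one measured step bears on this change: a 1.3-fold higher number from compound 1 to compound 2 (0.10 log units; within the scatter). That step exchanged two quite different groups in this same place, yet it stayed within the scatter. Going by the values given here, one step is thin evidence, and no phenoxy compound has been measured yet. Even so, no step beyond the scatter is expected in this assay, and neither direction is favoured. The expected change is a 1.1-fold lower number from compound 2 to compound 3 (0.04 log units; within the scatter). For compound 3 the estimated value is 10000 nM, with an expected range from 4000 nM to 25000 nM.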

Compound 3, half-maximal inhibitory concentration: 7900 nM
Estimate against measurement, compound 3: 1.3-fold (0.10 log units) above, within the range that was stated.
By their numbers in this assay, from the lowest: compounds 3, 1 and 2 (each within the scatter of the next).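

In this assay, phenoxy in place of phenyl gives a 1.4-fold lower number from compound 2 to compound 3 (0.14 log units; within the scatter), and phenoxy in place of heptyl gives a 1.1-fold lower number from compound 1 to compound 3 (0.04 log units; within the scatter). The earlier pair showed only that phenyl and heptyl could not be told apart at this position; the result now extends that to a third group, one that brings an oxygen link and a hydrogen-bond acceptor that phenyl lacks, and all three compounds still lie within the scatter of one another. No measured evidence is available to explain why these three groups read alike.

On these data alone, what remains open is whether this flat picture holds for quite different groups at this position, such as an amine, a carboxylic acid or a single methyl group, any of which might or might not produce a step beyond the scatter. The three compounds also share the rest of their structure, so they say nothing about whether a change elsewhere on the shared core would move the number more than these exchanges have.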